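The source may hold more compounds than are shown below. What is called first, only, known or untested is meant among the compounds shown, and "the series" means these compounds.

Measured compounds in an assay on HEK293 cells for binding affinity to Neuronal acetylcholine receptor; alpha4/beta2 (Homo sapiens); a higher number here means a weaker inhibitor, a lower number a stronger inhibitor:
Compound 1 `CC(=O)c1ccc2c(c1)C1CNCC2C1` gives 0.17 nM.
Compound 2 `N#Cc1ccc2c(c1)C1CNCC2C1` gives 0.5 nM.
Compound 3 `Nc1ccc2c(c1)C1CNCC2C1` gives 100 nM.

Compound 3 stands at the highest number of the three. Its nearest neighbour is compound 2, the step being a 200-fold higher number from compound 2 to compound 3 (2.30 log units; beyond the scatter), and the furthest is compound 1, with a 590-fold higher number from compound 1 to compound 3 (2.77 log units; beyond the scatter). Both steps are beyond the scatter, so compound 3 is the weakest of the measured set.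

Compound 4 `CC(=O)Nc1ccc2c(c1)C1CNCC2C1` differs from compound 3 by acetyl in place of hydrogen on a nitrogen on an aromatic ring. Among the compounds with values here, no measured pair repeats this exact change. Within the data shown here, the steps that bear on it are those from compound 1 and compound 2 to compound 3: replacing acetyl or cyano with amino raised the number greatly, and the entering acetyl carries one hydrogen-bond acceptor, as the groups of compound 1 and compound 2 do. This assay is therefore expected to move back toward lower numbers, though not necessarily all the way, since the acceptor now sits one bond further out on the nitrogen. The estimate for compound 4 in this assay is 20 nM, within 3 nM to 120 nM, meaning an expected step of a 5.0-fold lower number from compound 3 to compound 4 (0.70 log units; beyond the scatter).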

Compound 4, inhibition constant: 75 nM
Compound 4: middle estimate off by 3.8-fold (0.57 log units), on the low side, and the stated range covers the measured number.
By their numbers in this assay, from the lowest: compound 1; then compound 2; then compounds 4 and 3 (each within the scatter of the next).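

In this assay, acetyl in place of hydrogen on a nitrogen on an aromatic ring gives a 1.3-fold lower number from compound 3 to compound 4 (0.12 log units; within the scatter), so capping the amino group leaves compound 4 level with compound 3. The acceptor of the entering acetyl does not, on this nitrogen, recover what the groups on the aromatic carbon provide: the acetamido group stands apart from the other two, with a 150-fold higher number from compound 2 to compound 4 (2.18 log units; beyond the scatter) and a 440-fold higher number from compound 1 to compound 4 (2.64 log units; beyond the scatter). The data shown offer no measured explanation for this.

Going by these compounds, whether a carboxamide, joined through its carbon to the aromatic carbon, would fall with compound 1 and compound 2 or with compound 3 and compound 4 remains open. So does whether a longer acyl chain such as propanoyl, or a methanesulfonyl group, on the nitrogen would differ from acetyl.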